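Series notes on the step from compound 2 to compound 4

The compounds below may be only part of what the source reports. "The series", "measured", "known", "first", "only" and "open" are said of these compounds alone.

In a functional assay on MCF7 cells (Homo sapiens) for cytotoxicity, read by MTT assay, with a stated time of 72 h (on this read-out lower numbers stand for stronger inhibition of growth and higher numbers for weaker inhibition of growth), compound 2 `CCCCC[Se]c1nc([Se]CCCCC)c2ccccc2n1` gives 38400 nM. In this assay compound 3 `CSc1nc(NCc2ccccc2)c2ccccc2n1` gives 41500 nM, and compound 1 `COc1ccc(CNc2nc([Se]C)nc3ccccc23)cc1` gives 42200 nM. Compound 2 carries the lowest of the three numbers, yet its gaps to compound 3 and to compound 1 both lie within the scatter, so no order can be read among these three; all of them sit close together.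

Compound 4 `CCCCC[Se]c1nc(N)c2ccccc2n1` has not yet been measured. It differs from compound 2 in one place: one nitrogen atom in place of a group of 6 heavy atoms (5 carbon, 1 selenium; no ring), on an aromatic carbon. Among the measured compounds shown here, no pair of measured compounds shows this change on its own, so there is no measured step to lean on, and the three measured compounds offer no sign of any change beyond the scatter for any alteration at this part of the shared core.

The expected step is therefore a 1.2-fold higher number from compound 2 to compound 4 (0.07 log units; within the scatter), with nothing beyond the scatter of this assay expected in either direction. Compound 4 is estimated at 45000 nM, within a range of 20000 nM to 100000 nM.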

Compound 4, concentration for 50% growth inhibition: 28600 nM
Compound 4: the middle estimate sits 1.6-fold (0.20 log units) above what was measured, and the stated range covers the measured number.
By their numbers in this assay, from the lowest: compounds 4, 2, 3 and 1 (each within the scatter of the next).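

In this assay, this position now has its first measured step (a 1.3-fold lower number from compound 2 to compound 4 (0.13 log units; within the scatter)), and it lies within the scatter. On this aromatic carbon, next to the ring nitrogen, amino can therefore stand in place of the group of 6 heavy atoms (5 carbon, 1 selenium) without separating the two compounds, although this rests on a single pair, and the other group of 6 heavy atoms is the same in both. No measurement at hand bears on this result.

On these data alone, it stays open whether a hydroxyl or a dimethylamino group at this place would give a step beyond the scatter. Also open, as far as these compounds go, is whether amino would behave the same way with a heptyl chain on the remaining selenium.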